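From 2-hydroxyethyl to methoxymethyl on a shared core

The source may hold more compounds than are shown below. What is called first, only, known or untested is meant among the compounds shown, and "the series" means these compounds.

Measured in a functional assay on NCI-H460 cells (Homo sapiens) for cytotoxicity, read by sulforhodamine B assay, with a stated time of 3 days; a higher number here means a weaker inhibitor, a lower number a stronger inhibitor:
- compound 1 `OCc1cn(Cc2cccc(Cl)c2)c2ccccc12`: 19 nM
- compound 2 `OCc1cn(Cc2ccc(Cl)cc2)c2ccccc12`: 16 nM
- compound 3 `OCCc1cn(Cc2ccc(Cl)cc2)c2ccccc12`: > 31600 nM

Compound 3 stands at the end of the measured range, and its > 31600 nM is a limit and not a number. Compound 1 and compound 2 lie within the usual scatter of each other, so both count as strong in this assay.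

The next compound is compound 4 `COCc1cn(Cc2ccc(Cl)cc2)c2ccccc12`, which has the same atoms as compound 3, joined differently. The change is methoxy in place of hydroxymethyl on a saturated chain carbon bound to an aromatic carbon. The same difference can also be read as 2-hydroxyethyl to methoxymethyl.

Within the data shown here, only one measured step bears on this, and it is large: an at least 1900-fold higher number from compound 2 to compound 3 (3.29 log units; beyond the scatter). That step produced the 2-hydroxyethyl chain, and compound 4 no longer has it, so a move back toward a lower number, meaning a stronger inhibitor, is expected. With a single step to go on, its size is uncertain, and compound 4 could still end at the limit.

The expected change is an at least 31-fold lower number from compound 3 to compound 4 (1.49 log units; beyond the scatter). The estimate for compound 4 is 1000 nM, with an expected range of 30 nM to 31600 nM.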

Compound 4, half-maximal inhibitory concentration: 1990 nM
Compound 4: middle estimate off by 2.0-fold (0.30 log units), on the low side; the measured number falls inside the stated range.
By their numbers in this assay, from the lowest: compounds 2 and 1 (each within the scatter of the next); then compound 4. At a limit, above all of these: compound 3.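

The value of compound 3 is a limit and not a number: the limit of > 31600 nM in this assay, at which 1 of the 4 values shown sits. In this assay, joining the same atoms differently, with methoxy in place of hydroxymethyl, still gives a large change even on that limit: an at least 15-fold lower number from compound 3 to compound 4 (1.20 log units; beyond the scatter). Among these compounds, the gain is only partial, since methyl in place of hydrogen on the oxygen of the hydroxymethyl group gives a 120-fold higher number from compound 2 to compound 4 (2.09 log units; beyond the scatter), so at this position both the way the atoms are joined and the hydrogen on the oxygen matter, where the earlier compounds showed only the effect of a longer chain.

Going by these compounds, it remains open whether the loss seen with compound 4 comes from losing that hydrogen or from the added methyl. An aminomethyl group or a carboxylic acid at this position, or a longer ether such as ethoxymethyl, would help separate the two.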